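Notes on replacing a phenyl group in the series

A few compounds are considered here, and "the series" means these few. Any claim that something is new, unique, unknown or untested is made for them only; others in the source may bear on it.

In a functional assay for inhibition, with Homo sapiens as the target (on this read-out lower numbers stand for tighter binding and higher numbers for weaker binding), compound 1 (`O=C(O)CC/C=C\CC1COC(c2ccc3ccccc3c2)OC1c1cccnc1`) gives 1780 nM and compound 2 (`O=C(O)CC/C=C\CC1COC(c2cccc3ccccc23)OC1c1cccnc1`) gives 631 nM. Compound 3 (`CC(C)(Oc1ccccc1)C1OCC(C/C=C\CCC(=O)O)C(c2cccnc2)O1`) has the lowest number of the three (75.9 nM). Compound 4 (`CSc1ccc(OC(C)(C)C2OCC(C/C=C\CCC(=O)O)C(c3cccnc3)O2)c([N+](=O)[O-])c1`) differs from compound 3 in one place (a group of 11 heavy atoms (7 carbon, 1 nitrogen, 2 oxygen, 1 sulfur; one six-membered aromatic ring of carbon only) in place of a group of 6 heavy atoms (6 carbon; one six-membered aromatic ring of carbon only), on an oxygen on a saturated carbon), where the phenyl leaves.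

Going by the values given here, no measured step covers this exact change. The closest evidence comes from replacements of the group on a saturated ring carbon: a modest step (a 2.8-fold lower number from compound 1 to compound 2 (0.45 log units; beyond the scatter)), a large one (a 23-fold lower number from compound 1 to compound 3 (1.37 log units; beyond the scatter)) and another modest one (an 8.3-fold lower number from compound 2 to compound 3 (0.92 log units; beyond the scatter)). These show that the number in this assay responds to changes in that part of the structure, but they do not fix a direction for the new group. A modest step towards a lower number is expected, with real uncertainty (a 2.5-fold lower number from compound 3 to compound 4 (0.40 log units; beyond the scatter)). The estimated value for compound 4 is 30 nM (expected range 6 nM to 150 nM).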

Compound 4, dissociation constant: 4.47 nM
Beside the measured number, compound 4's estimate is 6.7-fold (0.83 log units) above it, and the stated range ends above it.
By their numbers in this assay, from the lowest: compound 4; then compound 3; then compound 2; then compound 1.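

Working at the oxygen on a saturated carbon, the replacement of phenyl by the larger group gives a 17-fold lower number from compound 3 to compound 4 (1.23 log units; beyond the scatter) in this assay. Going by these compounds alone, the earlier steps all changed the group on a saturated ring carbon, so this is the first sign that the number also responds to a change made here, with a six-membered aromatic ring of carbon only present on both sides of the step. The entering group has 11 heavy atoms against 6 and 3 hydrogen-bond acceptors against 0, but no measurement given here accounts for the size of the step.

The entering group brings a nitro group and a methylsulfanyl group together, and the compounds shown do not separate their contributions. They also leave open whether an amine or a chlorine in place of the nitro group would keep the number this low.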